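A few compounds are considered here, and "the series" means these few. Any claim that something is new, unique, unknown or untested is made for them only; others in the source may bear on it.

Compound 1 `CCC/N=C1\S/C(=C\c2ccc(C(=O)OCC(O)CO)cc2)C(=O)N1c1ccccc1O`: > 250000 nM
Compound 2 `CCC/N=C1\S/C(=C\c2ccc(C(=O)OCC3COC(=O)O3)cc2)C(=O)N1c1ccccc1O`: 79000 nM

For the measured compounds named here, in a physicochemical assay for solubility, read by nephelometry, measured as kinetic solubility (on this read-out higher numbers stand for higher solubility and lower numbers for lower solubility), compound 2 gives 79000 nM, the only exact number so far. Compound 1 reads > 250000 nM, which is a limit of the assay. Compound 3 `CCC/N=C1\S/C(=C\c2ccc(CCC(=O)OC)cc2)C(=O)N1c1ccccc1O` carries 2-(methoxycarbonyl)ethyl in place of ((2-oxo-1,3-dioxolan-4-yl)methoxy)carbonyl on an aromatic carbon. Going by the values given here, the sole measured guide is an at least 3.1-fold lower number from compound 1 to compound 2 (0.50 log units; beyond the scatter), a different change within the same substituent, so it offers only weak support. A further fall in this assay is expected, a step of a 4.0-fold lower number from compound 2 to compound 3 (0.60 log units; beyond the scatter) beyond the scatter. The estimate for compound 3 is 20000 nM, with an expected range of 4000 nM to 80000 nM.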

Compound 3, solubility: 79000 nM
For compound 3 the middle estimate is 4.0-fold (0.60 log units) below the measured one; the measured number falls inside the stated range.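

In this assay, 2-(methoxycarbonyl)ethyl in place of ((2-oxo-1,3-dioxolan-4-yl)methoxy)carbonyl on this aromatic carbon gives no change at the digits printed from compound 2 to compound 3 (within the scatter), so here a group with no ring and fewer hydrogen-bond acceptors reads like the ringed one. The (2,3-dihydroxypropoxy)carbonyl group of compound 1 stands apart, with an at least 3.1-fold lower number from compound 1 to compound 3 (0.50 log units; beyond the scatter). The reading of compound 1 is a limit, not a number: the limit of > 250000 nM in this assay, at which 1 of the 3 values shown sits.

As far as these compounds go, how far compound 1 lies past that limit stays open. So does how a carboxylic acid or an amine on this aromatic carbon would read.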